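Swapping the Urea Aryl Cap in a Pyrazoline Series

A few compounds are considered here, and "the series" means these few. Any claim that something is new, unique, unknown or untested is made for them only; others in the source may bear on it.

Measured compounds:
compound 1 `COc1ccc(NC(=O)N2N=C(c3ccc(Br)cc3)CC2c2ccc(F)cc2)cc1` – 447 nM
compound 2 `O=C(Nc1ccncc1)N1N=C(c2ccccc2)CC1c1ccc(F)cc1` – 202 nM

In an assay on HEK293 cells for inhibition of Voltage-dependent T-type calcium channel subunit alpha-1H (Homo sapiens), read by FLIPR and calcium flux, with a stated time of 3 min (a higher number here means a weaker inhibitor, a lower number a stronger inhibitor), compound 1 gives 447 nM, the highest of the two numbers at hand, so it is the weaker of the two inhibitors. Compound 2 differs from compound 1 at several positions. In this assay compound 2 gives 202 nM, a gap that lies beyond the usual scatter. Two changes are involved at once, so the two values alone cannot be pulled apart into separate contributions.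

Compound 3 `O=C(Nc1ccccn1)N1N=C(c2ccc(Br)cc2)CC1c1ccc(F)cc1` has not yet been measured. It keeps the shared core of compound 1 and differs from it in one place: pyridin-2-yl in place of 4-methoxyphenyl on an amide-type nitrogen. Going by the values given here, no measured pair shows exactly this change, so the size of the step can only be guessed. A nitrogen-containing six-membered ring sits on the same urea nitrogen in compound 2, and that compound gives the lower number, which makes a modest gain in potency for compound 3 plausible, though a step no larger than the scatter is also possible.

Compound 3 is therefore expected to show a step of a 1.7-fold lower number from compound 1 to compound 3 (0.24 log units; within the scatter) relative to compound 1. Compound 3 has an estimated value in this assay of 260 nM, within a range from 100 nM to 700 nM.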

Compound 3, half-maximal inhibitory concentration: 393 nM
Compound 3: middle estimate off by 1.5-fold (0.18 log units), on the low side, within the range that was stated.
By their numbers in this assay, from the lowest: compounds 2, 3 and 1 (each within the scatter of the next, the first and the last beyond it).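

In this assay, putting pyridin-2-yl in place of 4-methoxyphenyl on the amide-type nitrogen gives a single clean reading for this position (a 1.1-fold lower number from compound 1 to compound 3 (0.06 log units; within the scatter)), and that step is too small to separate the two groups. The earlier pair differed in more than one place, so it could not show what this aryl group contributes by itself; this pair shows that, with the rest of compound 1 held fixed, replacing the carbon-only ring and its methoxy group with a pyridine ring leaves the number within the usual scatter of repeat measurements. Nothing available here bears on what lies behind this outcome.

Going by these compounds, this single step says nothing about groups of a different kind on the same nitrogen, such as a simple alkyl chain, a benzyl group or a ring carrying a carboxylic acid, so how far the position can change before the number moves remains unknown. On these data alone, it is also open whether the same exchange would again give so small a step if the bromine on the shared core were replaced by a hydrogen or a methoxy group.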